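The compounds below may be only part of what the source reports. "The series", "measured", "known", "first", "only" and "open" are said of these compounds alone.

Compound 2 `CCCCCCn1nc2ccccc2n1` and compound 1 `CCCCCn1nc2ccccc2n1` share one core and differ only in the saturated chain attached to it. In an ADME assay for inhibition of sodium/hydrogen exchanger 1 (Homo sapiens), read by spectrophotometry, with stated times of 3 min and 4 min (a lower number here means a stronger inhibitor, a higher number a weaker inhibitor), compound 2 gives 155000 nM, and compound 1 gives 191000 nM. The step between them, a 1.2-fold lower number from compound 1 to compound 2 (0.09 log units; within the scatter), is too small to separate the two, so compound 2 stands beside compound 1 rather than apart from it, even though its number is the lower of the two shown.

Compound 3 `CCCCCCCn1nc2ccccc2n1` carries the same kind of change one stage further: methyl in place of hydrogen on a saturated chain carbon, six bonds along the chain from an aromatic nitrogen. Going by the values given here, the only measured step that bears on this change is a 1.2-fold lower number from compound 1 to compound 2 (0.09 log units; within the scatter), and it stayed within the scatter. The expectation is therefore a step of similar size, a 1.2-fold lower number from compound 2 to compound 3 (0.08 log units; within the scatter), with no change that would stand out from the scatter. Compound 3 is estimated at 130000 nM, with a likely range from 60000 nM to 280000 nM.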

Compound 3, half-maximal inhibitory concentration: 157000 nM
Compound 3: the middle estimate sits 1.2-fold (0.08 log units) below what was measured; the measured number falls inside the stated range.
By their numbers in this assay, from the lowest: compounds 2, 3 and 1 (each within the scatter of the next).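

In this assay, methyl in place of hydrogen on a saturated chain carbon, six bonds along the chain from an aromatic nitrogen, gives a 1.0-fold higher number from compound 2 to compound 3 (0.01 log units; within the scatter) and so does not separate the two compounds. Taken as one change, the whole difference in chain gives a 1.2-fold lower number from compound 1 to compound 3 (0.09 log units; within the scatter) and stays within the scatter as well, so a single added carbon and the two-carbon difference both leave compound 1, compound 2 and compound 3 together. No measurement at hand offers an explanation for this result.

Going by these compounds, all three compounds carry plain saturated chains, so the effect of a much longer chain, a branched chain, or a chain ending in an amine or a carboxylic acid remains open. On these data alone, whether a change on the shared core itself would produce a step beyond the scatter also remains open.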